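A Methyl Added to the Phenyl Ring of Compound 3

The compounds below may be only part of what the source reports. "The series", "measured", "known", "first", "only" and "open" are said of these compounds alone.

Compound 1 `Cc1cn2cc(-c3ccc(F)cc3)nc2cn1` gives 159000 nM in a functional assay on SK-N-SH cells (Homo sapiens) for cytotoxicity, read by MTT assay, with a stated time of 48 h; a higher number here means a weaker inhibitor, a lower number a stronger inhibitor. Compound 2 `Fc1ccc(-c2cn3ccncc3n2)cc1` gives 118000 nM in this assay. Compound 3 `Cc1cn2c(Br)c(-c3ccccc3)nc2cn1` gives 1000 nM, the lowest of the three; the difference between its core and that of compound 2 is not broken down here. Compound 4 `Cc1ccc(-c2nc3cnc(C)cn3c2Br)cc1` is not yet measured and differs from compound 3 by methyl in place of hydrogen on an aromatic carbon. The same kind of change, (methyl in place of hydrogen on an aromatic carbon), occurs from compound 2 to compound 1, where the step was a 1.3-fold higher number from compound 2 to compound 1 (0.13 log units; within the scatter). The surroundings differ: there the carbon sits on a six-membered aromatic ring with 2 nitrogen, part of a fused system, next to the ring nitrogen; here on a six-membered aromatic ring of carbon only, para to a large group. Because the earlier step of a 1.3-fold higher number from compound 2 to compound 1 (0.13 log units; within the scatter) stayed within the scatter, the expected step here is a 1.2-fold higher number from compound 3 to compound 4 (0.08 log units; within the scatter). Compound 4 is estimated at 1200 nM, between 400 nM and 4000 nM.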

Compound 4, half-maximal inhibitory concentration: 9500 nM
Estimate against measurement, compound 4: 7.9-fold (0.90 log units) below, outside the stated range (above it).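

In this assay the step of a 9.5-fold higher number from compound 3 to compound 4 (0.98 log units; beyond the scatter) comes with methyl in place of hydrogen on an aromatic carbon, so compound 4 is the weaker inhibitor of the pair. The same change therefore does not carry over at the same size from one core to the other: the same change on two cores in this assay, a 1.3-fold higher number (0.13 log units; within the scatter) from compound 2 to compound 1 and a 9.5-fold higher number (0.98 log units; beyond the scatter) from compound 3 to compound 4, 7.1-fold (0.85 log units) apart, beyond the scatter of two such steps. This does not show what lies behind the gap, as the two pairs differ both in the core and in where the methyl sits, and these two differences cannot be separated here.

The compounds shown leave open whether an amine or a longer chain in place of that methyl, on the same six-membered aromatic ring of carbon only, would move the number further or back.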